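A few compounds are considered here, and "the series" means these few. Any claim that something is new, unique, unknown or untested is made for them only; others in the source may bear on it.

Compound 1 `CCOc1ccc(NCN2C(=O)c3ccccc3C2=O)cc1` — an assay on isolated protein for inhibition of ribosomal protein S6 kinase alpha-2 (Homo sapiens), read by fluorescence, with a stated time of 20 min; a lower number here means a stronger inhibitor, a higher number a weaker inhibitor: 590 nM
Compound 2 `Cc1ccc(NCN2C(=O)c3ccc([N+](=O)[O-])cc3C2=O)cc1` — this assay: "not determined" (no result reported)

For the measured compounds named here, compound 1 is the only one with a number: in this assay compound 1 gives 590 nM. Compound 2 stands on no number at all, so its place cannot be told from what was measured. Compound 3 `CCOc1ccc(NCN2C(=O)c3ccc([N+](=O)[O-])cc3C2=O)cc1` differs from compound 2 by ethoxy in place of methyl on an aromatic carbon. Going by the values given here, with no measured step between compounds of this kind, the size and direction of this change cannot be foreseen, and no move beyond the usual scatter is assumed. Compound 3 is expected to give about 500 nM, with a range from 150 nM to 2000 nM.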

Compound 3, half-maximal inhibitory concentration: 2830 nM
For compound 3 the middle estimate is 5.7-fold (0.75 log units) below the measured one, outside the stated range (above it).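

In this assay, putting nitro in place of hydrogen on an aromatic carbon of the shared core gives a 4.8-fold higher number from compound 1 to compound 3 (0.68 log units; beyond the scatter), so the inhibitor becomes weaker. For the compounds shown here, this is the first sign that this position responds to a change, and for this one pair the change costs strength rather than adding it. Nothing measured here explains the loss.

The step from compound 2 to compound 3 cannot be read, as compound 2 has no number. On these data alone, whether an amine or a carboxylic acid at this same carbon would also weaken inhibition remains open.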